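Swapping Chlorines for Methoxy Groups on the Aryl Ketone

This account rests on a few compounds, and the source may have more. Where it says the series, first, only, none or still open, it means among the compounds named here.

Compound 1 `COc1cc(-c2cc(/C=C/C(=O)c3ccc(N)cc3)[nH]n2)cc(OC)c1OC` and compound 2 `COc1cc(-c2cc(/C=C/C(=O)c3ccc(Cl)c(Cl)c3)[nH]n2)cc(OC)c1OC` share one core and differ only in the aryl group on a carbonyl carbon. In a functional assay on SK-MEL-5 cells (Homo sapiens) for inhibition, read by sulforhodamine B assay, with a stated time of 48 h (on this read-out lower numbers stand for higher toxicity in this test and higher numbers for lower toxicity in this test), compound 1 gives 5690 nM. Compound 2 reaches only the limit of > 100000 nM, so no exact number is known for it. For the measured compounds named here, the single measured step, an at least 17-fold higher number from compound 1 to compound 2 (1.24 log units; beyond the scatter), is large. Compound 3 `COc1ccc(C(=O)/C=C/c2cc(-c3cc(OC)c(OC)c(OC)c3)n[nH]2)cc1OC` carries 3,4-dimethoxyphenyl in place of 3,4-dichlorophenyl on a carbonyl carbon. Going by the values given here, no measured pair covers this exchange; compound 1 merely shows that another aryl group on that carbon can give a far lower number. For compound 3 the expected step is an at least 4.0-fold lower number from compound 2 to compound 3 (0.60 log units; beyond the scatter), an estimate of 25000 nM, within 5000 nM to 100000 nM.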

Compound 3, concentration lethal to 50% of the cells: 5590 nM
For compound 3 the middle estimate is 4.5-fold (0.65 log units) above the measured one, within the range that was stated.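

On this carbonyl carbon, 3,4-dimethoxyphenyl in place of 3,4-dichlorophenyl gives an at least 17-fold lower number from compound 2 to compound 3 (1.25 log units; beyond the scatter), so a group other than 4-aminophenyl can also bring the number far down from the limit. The other step, a 1.0-fold lower number from compound 1 to compound 3 (0.01 log units; within the scatter), shows that 3,4-dimethoxyphenyl and 4-aminophenyl cannot be told apart in this assay. The value of compound 2 is a limit of the assay and not a number: the limit of > 100000 nM in this assay, at which 1 of the 3 values shown sits.

As far as these compounds go, what a plain phenyl, a 4-methoxyphenyl or a 4-chlorophenyl group would give on this carbon stays open.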